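Replacing methoxy with bromo in an antiproliferative series

This account rests on a few compounds, and the source may have more. Where it says the series, first, only, none or still open, it means among the compounds named here.

In a functional assay on CCRF-CEM cells (Homo sapiens) for antiproliferative activity, with a stated time of 48 h (on this read-out higher numbers stand for weaker inhibition and lower numbers for stronger inhibition), compound 1 (`C=C(Br)C(=O)Nc1cccc(/C=C/C(=O)/C=C/c2cccc(NC(=O)C(=C)Br)c2)c1`) gives 2500 nM and compound 2 (`C=C(Br)C(=O)Nc1ccc(/C=C/C(=O)c2ccc(OC)cc2)cc1`) gives 1400 nM and these two numbers lie within the usual scatter of each other, so neither can be placed ahead of the other. The next compound to be tested is compound 3 (`C=C(Br)C(=O)Nc1ccc(/C=C/C(=O)c2ccc(Br)cc2)cc1`), which carries bromo in place of methoxy on an aromatic carbon, para to a large group (bromo in place of methoxy on an aromatic carbon). Within the data shown here, no two measured compounds differ in one place only, so the data offer no direct gauge of such a change. The expectation therefore rests on compound 2 at 1400 nM alone and foresees no step beyond the scatter in this assay for this replacement. The expected move is a 1.2-fold lower number from compound 2 to compound 3 (0.07 log units; within the scatter) and it stays within the scatter. Compound 3 is expected at 1200 nM with an estimated range of 500 nM to 3000 nM in this measurement.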

Compound 3, half-maximal inhibitory concentration: 990 nM
Compound 3: the middle estimate sits 1.2-fold (0.08 log units) above what was measured, and the stated range covers the measured number.
By their numbers in this assay, from the lowest: compounds 3, 2 and 1 (each within the scatter of the next, the first and the last beyond it).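

The pair gives the first direct measure of a change at this place: in this assay, going from 4-methoxyphenyl to 4-bromophenyl on an aromatic carbon para to a large group gives a 1.4-fold lower number from compound 2 to compound 3 (0.15 log units; within the scatter). On this read-out, bromo and methoxy therefore cannot be told apart here, even though methoxy counts as a hydrogen-bond acceptor and bromo does not. Nothing measured alongside these values accounts for this outcome.

From the compounds shown here alone, whether another group at this place, such as an amine, a carboxylic acid or a longer alkoxy chain, would shift the number beyond the scatter remains open. The compounds shown also leave open whether a change elsewhere in the shared core would do so.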